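Replacing acetyl with methylsulfanyl on the aryl amine

A few compounds are considered here, and "the series" means these few. Any claim that something is new, unique, unknown or untested is made for them only; others in the source may bear on it.

Of the compounds shown here, three built on a shared core have been measured in a functional assay (aorta) with Rattus norvegicus as the target; a lower number here means a stronger inhibitor, a higher number a weaker inhibitor. Compound 1 `CC1(C)Oc2ccc(C#N)cc2[C@@H](/N=C(\NC#N)Nc2cccc(Cl)c2)[C@@H]1O` gives 600 nM, compound 2 `CC1(C)Oc2ccc(C#N)cc2[C@@H](/N=C(\NC#N)Nc2cccc(C(F)(F)F)c2)[C@@H]1O` gives 1600 nM, and compound 3 `CC(=O)c1ccc(N/C(=N/[C@@H]2c3cc(C#N)ccc3OC(C)(C)[C@H]2O)NC#N)cc1` gives 21000 nM, the highest number of the three. The step of a 2.7-fold higher number from compound 1 to compound 2 (0.43 log units; beyond the scatter) was modest, whereas a 35-fold higher number from compound 1 to compound 3 (1.54 log units; beyond the scatter) and a 13-fold higher number from compound 2 to compound 3 (1.12 log units; beyond the scatter) were both large, setting compound 3 well apart from the other two in this assay.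

Compound 4 `CSc1ccc(N/C(=N/[C@@H]2c3cc(C#N)ccc3OC(C)(C)[C@H]2O)NC#N)cc1` differs from compound 3 in one place: methylsulfanyl in place of acetyl on an aromatic carbon. Among the measured compounds shown here, none of the measured steps exchanges one group for another on the same aromatic carbon of the phenyl ring, so no step bears directly on this change; the measured steps only show that the group on the aryl amine can move this assay by a large margin. The author therefore expects a modest step, a 2.3-fold lower number from compound 3 to compound 4 (0.37 log units; beyond the scatter), toward a somewhat lower number, with wide uncertainty. Compound 4 is estimated at 9000 nM, with a range from 2500 nM to 30000 nM.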

Compound 4, half-maximal inhibitory concentration: 6300 nM
Compound 4: the middle estimate sits 1.4-fold (0.15 log units) above what was measured; low and high end bracket the measured number.
By their numbers in this assay, from the lowest: compound 1; then compound 2; then compound 4; then compound 3.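

In this assay, the group on this aromatic carbon, para to a large group, changes the number by itself: a 3.3-fold lower number from compound 3 to compound 4 (0.52 log units; beyond the scatter) when methylsulfanyl replaces acetyl. The gain is only partial, as 4-(methylsulfanyl)phenyl still trails both other aryl groups, with a 3.9-fold higher number from compound 2 to compound 4 (0.60 log units; beyond the scatter) against 3-(trifluoromethyl)phenyl and an 11-fold higher number from compound 1 to compound 4 (1.02 log units; beyond the scatter) against 3-chlorophenyl. Nothing available here explains why methylsulfanyl and acetyl differ in this way.

The compounds shown leave open how a methoxy group, an amine or a carboxylic acid on this same carbon would read in this assay. They also leave open whether methylsulfanyl would give a lower number than acetyl on the ring carbon that carries the chloro group in compound 1.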